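Single stereocentre inversion in a low-inhibition pair

This account rests on a few compounds, and the source may have more. Where it says the series, first, only, none or still open, it means among the compounds named here.

Measured compounds:
compound 1, `OC[C@H]1O[C@@H](c2noc(-c3ccccc3)n2)C[C@@H]1O`, 10%
compound 2, `Cc1nc([C@@H]2C[C@H](O)[C@@H](CO)O2)no1`, 10%

In a functional assay on SK-OV-3 cells (Homo sapiens) for inhibition, read by MTT assay, with a stated time of 72 h, tested at 10 uM (on this read-out lower numbers stand for less inhibition and higher numbers for more inhibition at the one concentration tested (going by the name of the read-out)), compound 1 gives 10%. Compound 2 gives 10% in this assay. Compound 2 therefore stands level with compound 1 at the digits shown, and the two values lie within the scatter of each other; no ordering between them can be read from these numbers. Within the data shown here, the pair differs in more than one place, so no single-change step between measured compounds is available from which a sensitivity of this assay to structure could be taken.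

Compound 3 is `Cc1nc([C@H]2C[C@H](O)[C@@H](CO)O2)no1`. Against compound 2 the difference is the two compounds have the same atoms and bonds and differ only in configuration as drawn: 1 of 3 stereo elements differ; a stereocentre at a saturated ring carbon is drawn S in compound 2 and R in compound 3.

Among the measured compounds shown here, with both measured compounds sitting at the same low inhibition, the only guide for compound 3 is that low level. The step from compound 2 to compound 3 is expected to be no change at the digits printed from compound 2 to compound 3 (within the scatter), that is, nothing beyond the scatter in either direction. Compound 3 is estimated to give 10% in this assay, with a range from 0% to 25%. A reading within the scatter of compound 2 is the expectation here; a larger move would be outside what the pair so far supports.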

Compound 3, a percentage reported as inhibition, at one concentration (the size of the read-out at that concentration, not a potency): 10%
Beside the measured number, compound 3's estimate shows no gap at the digits printed, and the stated range covers the measured number.
By their numbers in this assay, from the lowest: compounds 1, 2 and 3 (each within the scatter of the next).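

In this assay, inverting the saturated ring carbon from S to R gives no change at the digits printed from compound 2 to compound 3 (within the scatter), so within this pair the drawn configuration at this stereocentre produces no reading beyond the scatter. This comparison isolates a single stereo element: the fact that compounds 2 and 3 differ only in the configuration as drawn. Among these compounds, the result also supplies the first single-place comparison at the aromatic carbon, where methyl in place of phenyl gives no change at the digits printed from compound 1 to compound 3 (within the scatter), so neither change separates the compounds in this assay at the one concentration tested.

All three compounds sit at the same low inhibition, so these results cannot show whether either position would matter in a compound with a higher reading, or whether the other two stereo elements would behave as this one does. Also open, from the compounds shown here alone, is whether an amine, a carboxylic acid or a longer chain in place of methyl or phenyl on the aromatic carbon would move the reading in this assay beyond the scatter.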